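Compound 3: 4-chlorophenyl in place of 2-chlorophenyl

The source may hold more compounds than are shown below. What is called first, only, known or untested is meant among the compounds shown, and "the series" means these compounds.

Measured in a functional assay on NCI/ADR cells (Homo sapiens) for cytotoxicity, read by sulforhodamine B assay; on this read-out higher numbers stand for weaker inhibition of growth and lower numbers for stronger inhibition of growth:
- Compound 1 `CC1=CC[C@@H]([C@@](C)(O)CCCC(C)(C)NC(=S)N/N=C\c2ccc(O)cc2)CC1`: 6070 nM
- Compound 2 `CC1=CC[C@@H]([C@@](C)(O)CCCC(C)(C)NC(=S)N/N=C\c2ccccc2Cl)CC1`: > 100000 nM (a limit of the assay, not a number)

Compound 2 stands at > 100000 nM, which is a limit of the assay and not a number. Compound 3 `CC1=CC[C@@H]([C@@](C)(O)CCCC(C)(C)NC(=S)N/N=C\c2ccc(Cl)cc2)CC1` has 4-chlorophenyl in place of 2-chlorophenyl on a carbon with a double bond to nitrogen. For the measured compounds named here, the one measured step at this place, an at least 16-fold higher number from compound 1 to compound 2 (1.21 log units; beyond the scatter), was large and replaced the 4-hydroxyphenyl of compound 1. The 4-chlorophenyl of compound 3 resembles both earlier groups, so a lower number in this assay is expected, though with little certainty. The expected step is an at least 3.3-fold lower number from compound 2 to compound 3 (0.52 log units; beyond the scatter). For compound 3 the estimate is 30000 nM, with an expected range from 6000 nM to 100000 nM.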

Compound 3, concentration for total growth inhibition: 36400 nM
Beside the measured number, compound 3's estimate is 1.2-fold (0.08 log units) below it; the range from low to high includes it.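

In this assay, 4-chlorophenyl in place of 2-chlorophenyl gives an at least 2.7-fold lower number from compound 2 to compound 3 (0.43 log units; beyond the scatter), so the place of the chlorine on the ring matters, not only its presence. Compound 2 has a limit of the assay and not a number, so this step has no upper end: the limit of > 100000 nM in this assay, at which 1 of the 3 values shown sits.

With the place on the ring unchanged, chloro in place of hydroxy gives a 6.0-fold higher number from compound 1 to compound 3 (0.78 log units; beyond the scatter), so the choice of group matters as well. The compounds shown leave open how a 4-methoxyphenyl or a 4-aminophenyl would compare with the 4-hydroxyphenyl of compound 1.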